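Isopropylcarbonyl to isopropylsulfonyl: a step among limits

The source may hold more compounds than are shown below. What is called first, only, known or untested is meant among the compounds shown, and "the series" means these compounds.

Measured so far in an ADME assay on Vero cells (Chlorocebus sabaeus) for cytotoxicity, read by MTT assay, with a stated time of 48 h; a higher number here means a weaker inhibitor, a lower number a stronger inhibitor:
Compound 1 `O=C(OC1CCC(CN2CCN(c3cc(=O)c4cc(C(F)(F)F)cc([N+](=O)[O-])c4s3)CC2)CC1)c1ccccc1`: > 64 ug/mL
Compound 2 `CS(=O)(=O)OC1CCC(CN2CCN(c3cc(=O)c4cc(C(F)(F)F)cc([N+](=O)[O-])c4s3)CC2)CC1`: > 64 ug/mL
Compound 3 `CC(C)C(=O)OC1CCC(CN2CCN(c3cc(=O)c4cc(C(F)(F)F)cc([N+](=O)[O-])c4s3)CC2)CC1`: > 64 ug/mL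

Compound 3 gives > 64 ug/mL as a limit of the assay and not as a number. Going by the values given here, the series so far shows the same picture, with the limit of > 64 ug/mL in this assay, at which 3 of the 3 values shown sit, and no exact value to compare.

Compound 4 `CC(C)S(=O)(=O)OC1CCC(CN2CCN(c3cc(=O)c4cc(C(F)(F)F)cc([N+](=O)[O-])c4s3)CC2)CC1` keeps the shared core and changes one group on an oxygen on a saturated carbon, with isopropylsulfonyl in place of isopropylcarbonyl (isopropylsulfonyl in place of isopropylcarbonyl on an oxygen on a saturated carbon).

The closest measured change is a step that the two limits leave unreadable from compound 2 to compound 3 and it also exchanges a sulfonyl group and a carbonyl group on that oxygen. The changes a step that the two limits leave unreadable from compound 1 to compound 2 and a step that the two limits leave unreadable from compound 1 to compound 3 touch the same group. None of these steps has a readable size. Compound 2 carries methylsulfonyl on that oxygen and gives > 64 ug/mL as a limit, so no step beyond the scatter is expected in this assay for the new sulfonyl group.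

The expected outcome is a step that the limit leaves unreadable from compound 3 to compound 4 and the assay will probably report only a limit again. For compound 4 the estimate is 80 ug/mL with 40 ug/mL to 160 ug/mL as the expected range.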

Compound 4, half-maximal inhibitory concentration: > 64 ug/mL
Compound 4 was reported as a limit (the forecaster's own chance of this, stated with the estimate: 85%); the middle value lies beyond the limit too.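

In this assay compound 4 gives > 64 ug/mL, a limit of the assay and not a number. Going by these compounds alone, no step linking compound 4 to compound 1, compound 2 or compound 3 can be read, because all four stand at the same limit: the limit of > 64 ug/mL in this assay, at which 4 of the 4 values shown sit. The compounds shown leave open where each true value lies and whether exchanging the group on that oxygen changes the result at all.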